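This account rests on a few compounds, and the source may have more. Where it says the series, first, only, none or still open, it means among the compounds named here.

Compound 1 `O=C(/C=C/c1ccc([N+](=O)[O-])o1)c1ccc(-c2ccccc2)cc1` has been tested in an ADME assay on THP-1 cells (Homo sapiens) for cytotoxicity, read by resazurin assay, with a stated time of 72 h (on this read-out higher numbers stand for lower toxicity in this test and lower numbers for higher toxicity in this test), where compound 1 gives 50400 nM. Compound 2 `CCCCc1ccc(C(=O)/C=C/c2ccc([N+](=O)[O-])o2)cc1` carries a butyl group where compound 1 carries phenyl, and in this assay compound 2 gives 48700 nM; the step of a 1.0-fold lower number from compound 1 to compound 2 (0.01 log units; within the scatter) lies within the scatter. Compound 3 `O=C(/C=C/c1ccc([N+](=O)[O-])o1)c1ccc(N2CCCC2)cc1` carries pyrrolidin-1-yl in the same position. In this assay compound 3 returns only a limit of the assay, > 50000 nM, so no number is known for it. Compound 3 thus stands at the limit (the limit of > 50000 nM in this assay, at which 1 of the 3 values shown sits), while the values of compounds 1 and 2 are numbers in the same region. The step that the limit leaves unreadable from compound 1 to compound 3 cannot be sized, and the step of an at least 1.0-fold higher number from compound 2 to compound 3 (0.01 log units; that floor lies within the scatter) has only a floor.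

Compound 4 `O=C(/C=C/c1ccc([N+](=O)[O-])o1)c1ccc(Br)cc1` differs from compound 3 by bromo in place of pyrrolidin-1-yl on an aromatic carbon. Among the compounds with values here, no measured step involves bromo; the two steps that can be read, a 1.0-fold lower number from compound 1 to compound 2 (0.01 log units; within the scatter) and an at least 1.0-fold higher number from compound 2 to compound 3 (0.01 log units; that floor lies within the scatter), show that exchanging the group at this position among phenyl, butyl and pyrrolidin-1-yl moved the value in this assay by no more than the scatter. The step from compound 3 to compound 4 is therefore expected to be a number no higher from compound 3 to compound 4 (the limit leaves the size open). Compound 4 is expected to give about 50000 nM in this assay, between 25000 nM and 100000 nM, and it may again return only the limit of the assay.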

Compound 4, half-maximal cytotoxic concentration: 13400 nM
Compound 4: the middle estimate sits 3.7-fold (0.57 log units) above what was measured; the whole stated range lies above it.
By their numbers in this assay, from the lowest: compound 4; then compounds 2 and 1 (each within the scatter of the next).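

In this assay this position proved able to move the number after all: bromo in place of butyl gives a 3.6-fold lower number from compound 2 to compound 4 (0.56 log units; beyond the scatter), and bromo in place of phenyl gives a 3.8-fold lower number from compound 1 to compound 4 (0.58 log units; beyond the scatter), whereas the exchanges among phenyl, butyl and pyrrolidin-1-yl had shown no step beyond the scatter. Bromo in place of pyrrolidin-1-yl gives an at least 3.7-fold lower number from compound 3 to compound 4 (0.57 log units; beyond the scatter), which sets compound 4 apart from all three earlier compounds as the one with the highest toxicity in this test, so the shared core alone does not fix the number. That last step is only a floor, and its true size stays unknown, because compound 3 gives a limit of the assay and not a number: the limit of > 50000 nM in this assay, at which 1 of the 4 values shown sits.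

The compounds shown leave open whether the lower number belongs to bromo alone or would also appear with chloro, fluoro or methyl at this place. They also leave open whether an open-chain amine, a carboxylic acid or a chain longer than butyl would stay with phenyl, butyl and pyrrolidin-1-yl or move towards bromo.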